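A Larger Aryl Group on the Sulfonyl Sulfur

A few compounds are considered here, and "the series" means these few. Any claim that something is new, unique, unknown or untested is made for them only; others in the source may bear on it.

Of the compounds shown here, two sharing one core have been measured so far. Compound 1 `COc1cc2nc(N3CCN(S(=O)(=O)c4ccc(C)cc4)CC3)nc(N)c2cc1OC` gives 30000 nM in a functional assay on PC-3 cells (Homo sapiens) for inhibition; a lower number here means a stronger inhibitor, a higher number a weaker inhibitor. Compound 2 `COc1cc2nc(N3CCN(S(=O)(=O)c4cccc(C(=O)O)c4)CC3)nc(N)c2cc1OC` differs from compound 1 only in the aryl group on the sulfonyl sulfur; in this assay compound 2 gives 53000 nM. Compound 2 thus holds the higher of the two numbers, but the gap is only a 1.8-fold higher number from compound 1 to compound 2 (0.25 log units; within the scatter), so the two cannot really be told apart. Compound 3 `COc1cc2nc(N3CCN(S(=O)(=O)c4ccc(-c5ccccc5)cc4)CC3)nc(N)c2cc1OC` has not yet been measured. Its difference from compound 2 is 4-phenylphenyl in place of 3-carboxyphenyl on a sulfonyl sulfur. Within the data shown here, the one measured step that bears on this change is a 1.8-fold higher number from compound 1 to compound 2 (0.25 log units; within the scatter), which also swapped the aryl group on the sulfonyl sulfur and stayed within the scatter. Among the measured compounds shown here, on that basis no step beyond the scatter is expected in this assay for compound 3, though a single within-scatter step is thin evidence and the new group has no measured precedent here. Compound 3 is therefore expected to give about 30000 nM in this assay, between 8000 nM and 110000 nM, a step of a 1.8-fold lower number from compound 2 to compound 3 (0.25 log units; within the scatter) that is an estimate rather than a measurement.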

Compound 3, half-maximal inhibitory concentration: 4200 nM
Beside the measured number, compound 3's estimate is 7.1-fold (0.85 log units) above it, and the stated range ends above it.
By their numbers in this assay, from the lowest: compound 3; then compounds 1 and 2 (each within the scatter of the next).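

The aryl group on the sulfonyl sulfur can matter in this assay after all: the earlier swap at this position stayed within the scatter, whereas 4-phenylphenyl in place of 3-carboxyphenyl gives a 13-fold lower number from compound 2 to compound 3 (1.10 log units; beyond the scatter) and is a large step. Among these compounds, the cleanest reading comes from the other comparison, since only one group changes, phenyl in place of methyl on an aromatic carbon, and that gives a 7.1-fold lower number from compound 1 to compound 3 (0.85 log units; beyond the scatter), a modest step beyond the scatter that sets compound 3 apart from both earlier compounds. Nothing available here accounts for why the number falls with this change.

The compounds shown leave open whether an aromatic ring is needed on that carbon at all, or whether a saturated ring such as cyclohexyl, or a longer alkyl chain, would lower the number in the same way. They also leave open how far the outer phenyl ring can be altered, for instance whether an amine or a methoxy group on it would keep, lose or extend the step seen with compound 3.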